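This account rests on a few compounds, and the source may have more. Where it says the series, first, only, none or still open, it means among the compounds named here.

Measured compounds in a functional assay on MGC-803 cells (Homo sapiens) for antiproliferative activity, read by CCK-8 assay, with a stated time of 72 h, tested at 2 uM; on this read-out higher numbers stand for a stronger effect at the one concentration tested and lower numbers for a weaker effect:
compound 1, `Nc1ccccc1NC(=O)c1ccc(CSC(=S)N2CCc3ccccc32)cc1`, 44%
compound 2, `CN(C(=S)SCc1ccc(C(=O)Nc2ccccc2N)cc1)c1cccnc1`, 46.1%
compound 3, `CN(Cc1ccncc1)C(=S)SCc1ccc(C(=O)Nc2ccccc2N)cc1`, 38.1%

Compound 1 stands second highest of the three numbers; its nearest neighbour is compound 2, with a number 2.1 percentage points higher from compound 1 to compound 2 (within the scatter), and its furthest is compound 3, with a number 5.9 percentage points lower from compound 1 to compound 3 (within the scatter). Compound 4, `Nc1ccccc1NC(=O)c1ccc(CSC(=S)N2CCc3cc([N+](=O)[O-])ccc32)cc1`, differs from compound 1 by nitro in place of hydrogen on an aromatic carbon. For the measured compounds named here, no measured step bears on this position: the three steps recorded, including a number 8 percentage points lower from compound 2 to compound 3 (within the scatter), all vary the amine on the thiocarbonyl carbon and all stay within the scatter. The step from compound 1 to compound 4 is therefore expected to be no change at the digits printed from compound 1 to compound 4 (within the scatter), not beyond the scatter. Compound 4 is estimated at 44% in this assay, between 28% and 60%.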

Compound 4, a percentage reported as inhibition, at one concentration (the size of the read-out at that concentration, not a potency): 26.8%
Estimate against measurement, compound 4: 17.2 percentage points above; measured number outside the range, below it.
By their numbers in this assay, from the lowest: compound 4; then compounds 3, 1 and 2 (each within the scatter of the next).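

The earlier steps shown here all varied the amine on the thiocarbonyl carbon and stayed within the scatter. In this assay, nitro in place of hydrogen on an aromatic carbon of the fused system of two rings gives a number 17.2 percentage points lower from compound 1 to compound 4 (beyond the scatter), the only step shown that goes beyond the scatter, and it marks this position as one where a substituent can change the read-out. Nothing available explains this drop. The compounds shown leave open whether an amine, a methoxy group or fluorine on this aromatic carbon would lower the number as nitro does, or whether the drop is particular to nitro.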